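The source may report more compounds than this note shows. Statements on the series, on what has been measured and on what is new or still open speak of the compounds shown alone.

Within the data shown here, compound 2 `Nc1scc(CN2CCN(c3cc(F)ccc3F)CC2)c1C(=O)c1ccc(Cl)cc1` stands highest of the two numbers so far in a functional assay on CHO cells with adenosine receptor A1 (Homo sapiens) as the target, read by cAMP accumulation and immunoassay, with a stated time of 6 min, tested at 1 uM (a lower number here means a stronger effect, a higher number a weaker effect of the compound at the concentration tested), where compound 2 gives -59%. Among the measured compounds shown here, compound 1 `Nc1scc(CN2CCN(c3cccc(C(F)(F)F)c3)CC2)c1C(=O)c1ccc(Cl)cc1` gives -72% in this assay, and the only measured step is a number 13 percentage points higher from compound 1 to compound 2 (beyond the scatter). Compound 3 `Nc1scc(CN2CCN(CCCc3ccc(Cl)cc3)CC2)c1C(=O)c1ccc(Cl)cc1` differs from compound 2 by 3-(4-chlorophenyl)propyl in place of 2,5-difluorophenyl on an amine nitrogen in a ring. For the measured compounds named here, that earlier step bears on it only loosely, as both changes sit on the amine nitrogen in a ring; no measured step covers a 3-(4-chlorophenyl)propyl entering there, so the expected step of a number 4 percentage points higher from compound 2 to compound 3 (within the scatter) is small and uncertain in direction. Compound 3 is estimated at -55%, between -85% and -20%.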

Compound 3, a percentage reported as activity, at one concentration (the size of the read-out at that concentration, not a potency): -30%
For compound 3 the middle estimate is 25 percentage points below the measured one; the range from low to high includes it.
By their numbers in this assay, from the lowest: compound 1; then compound 2; then compound 3.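

In this assay, replacing a phenyl group on the amine nitrogen in a ring with 3-(4-chlorophenyl)propyl weakens the effect, giving a number 29 percentage points higher from compound 2 to compound 3 (beyond the scatter) and a number 42 percentage points higher from compound 1 to compound 3 (beyond the scatter). This position can therefore shift the read-out further than the two phenyl-bearing compounds alone showed, although compound 3 still gives -30%. Nothing measured here explains the change. Still open, as far as these compounds go, is whether the propyl chain or the chlorine drives the shift, and whether a shorter link such as benzyl or an unsubstituted 3-phenylpropyl would behave likewise.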